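This account rests on a few compounds, and the source may have more. Where it says the series, first, only, none or still open, it means among the compounds named here.

In a functional assay on KB 3-1 cells (Homo sapiens) for cytotoxicity, read by MTT assay, with a stated time of 72 h (a higher number here means a weaker inhibitor, a lower number a stronger inhibitor), compound 3 (`O=C1Nc2ccccc2/C1=N/NC(=S)Nc1ccc(F)cc1`) gives 14200 nM. Compound 2 (`O=C1Nc2ccccc2/C1=N/NC(=S)Nc1cccc(Cl)c1`) gives 1870 nM, so compound 3 has the higher of the two actual numbers. Compound 1 (`O=C1Nc2ccccc2/C1=N/NC(=S)Nc1cccnc1`) gives > 50000 nM, which is a limit of the assay and not a number.

Compound 4 (`O=C1Nc2ccccc2/C1=N/NC(=S)Nc1ccc(Oc2ccccc2)cc1`) keeps the framework of compound 3 but carries phenoxy in place of fluoro on an aromatic carbon, para to a large group: phenoxy in place of fluoro on an aromatic carbon.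

Going by the values given here, no measured compound carries phenoxy, so the evidence is indirect. The measured steps all change the group on the amide-type nitrogen. The change an at least 26-fold lower number from compound 1 to compound 2 (1.42 log units; beyond the scatter) is large, and the change an at least 3.5-fold lower number from compound 1 to compound 3 (0.54 log units; beyond the scatter) is at least modest. The change a 7.6-fold higher number from compound 2 to compound 3 (0.88 log units; beyond the scatter) is modest and shows that swapping one substituted phenyl for another can shift the number beyond the scatter. Compound 2 at 1870 nM also shows that this family can reach lower numbers than compound 3.

A modest shift to a lower number is therefore expected, a 3.6-fold lower number from compound 3 to compound 4 (0.55 log units; beyond the scatter). For compound 4 the estimated value is 4000 nM, with an expected range from 1000 nM to 15000 nM.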

Compound 4, half-maximal inhibitory concentration: 5720 nM
The estimate for compound 4 lay 1.4-fold (0.16 log units) below the measured number, within the range that was stated.
By their numbers in this assay, from the lowest: compound 2; then compound 4; then compound 3. At a limit, above all of these: compound 1.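

The earlier steps shown here swapped the whole group on the amide-type nitrogen, whereas this one keeps the phenyl ring and changes a single substituent on an aromatic carbon, para to a large group. Replacing fluoro, a single heavy atom, with phenoxy, which brings seven heavy atoms and a second aromatic ring, gives a 2.5-fold lower number from compound 3 to compound 4 (0.39 log units; beyond the scatter). In this assay, this position therefore accepts a far bulkier group without the number rising, and the number in fact falls beyond the usual scatter.

Going by these compounds alone, only two groups are compared at this position, so it remains open whether an amine, a carboxylic acid or a longer chain such as benzyloxy would lower the number further or raise it. Nothing shown here bears on what lies behind this shift.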